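A few compounds are considered here, and "the series" means these few. Any claim that something is new, unique, unknown or untested is made for them only; others in the source may bear on it.

Working notes on the series. In a functional assay on Bel-7402 cells (Homo sapiens) for inhibition, read by MTT assay, with a stated time of 24 h, tested at 0.1 ug/mL (on this read-out higher numbers stand for more inhibition of growth at the one concentration tested and lower numbers for less inhibition of growth), compound 1 `O=C(CCCCC(S)CCS)Nc1ccccc1` gives 0.85%. Compound 2 `O=C(CCCCC(S)CCS)Nc1ccccc1Cl` gives 5.11%, and compound 3 `O=C(CCCCC(S)CCS)Nc1cccc(C(F)(F)F)c1` gives 2.85%. Compound 1 thus stands level with the other two measured compounds within the scatter, and all three numbers are small.

The next structure is compound 4 `COc1ccc(NC(=O)CCCCC(S)CCS)cc1`, which differs from compound 1 as follows: methoxy in place of hydrogen on an aromatic carbon. This is methoxy in place of hydrogen on an aromatic carbon, para to a large group.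

Within the data shown here, two measured steps bear on this change, since each also replaces hydrogen on an aromatic carbon. Chloro gives a number 4.3 percentage points higher from compound 1 to compound 2 (within the scatter), and trifluoromethyl gives a number 2 percentage points higher from compound 1 to compound 3 (within the scatter). Among the measured compounds shown here, neither step leaves the scatter, although the data contain no measured compound with methoxy, so this transfer is uncertain. No step beyond the scatter is expected in this assay, and any shift is expected to be small and upward at most. The expected step is a number 3.2 percentage points higher from compound 1 to compound 4 (within the scatter). For compound 4 the estimated value is 4%, with an expected range from 0% to 12%.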

Compound 4, percent growth inhibition at one concentration: 5.35%
Compound 4: middle estimate off by 1.4 percentage points, on the low side; measured number inside the range.
By their numbers in this assay, from the lowest: compounds 1, 3, 2 and 4 (each within the scatter of the next).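

In this assay, among these compounds, methoxy in place of hydrogen on an aromatic carbon, para to a large group, gives a number 4.5 percentage points higher from compound 1 to compound 4 (within the scatter), the first reading for a group at this place on the ring and the first for a group holding oxygen. Set with the earlier steps, a number 4.3 percentage points higher from compound 1 to compound 2 (within the scatter) and a number 2 percentage points higher from compound 1 to compound 3 (within the scatter), it shows that all three replacements on the ring of the shared core so far stay inside the scatter, and no compound shown goes against this. The change at this position therefore separates compound 4 from compound 1 no more clearly than chloro or trifluoromethyl did elsewhere on the ring, and nothing at hand explains the result or ties it to any property of the group.

Still open, from the compounds shown here alone, is whether an amine or a carboxylic acid at this same place, or a longer alkoxy chain in place of methoxy, would move the number beyond the scatter. Also open, going by these compounds, is whether methoxy elsewhere on the ring, or a change to the dithiol chain itself, would separate these compounds in this read-out.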